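Swapping methylsulfanyl for methoxy on a urea of compound 1

A few compounds are considered here, and "the series" means these few. Any claim that something is new, unique, unknown or untested is made for them only; others in the source may bear on it.

Measured so far:
compound 1, `CSc1ccccc1NC(=O)Nc1cc(C)nc2ccccc12`, in an ADME assay on BJ cells (Homo sapiens) for cytotoxicity, with a stated time of 72 h (on this read-out higher numbers stand for an effect only at larger amounts of compound and lower numbers for an effect already at smaller amounts), compound 1 gives > 25000 nM.
compound 2, `Cc1cc(NC(=O)Nc2ccc(OC(F)(F)F)cc2)c2ccccc2n1`, in this assay compound 2 gives 25000 nM.

For compound 1 the value is a limit of the assay, not a number. Compound 1 therefore stands only at the edge of what this assay can report, as the limit of > 25000 nM in this assay, at which 1 of the 2 values shown sits. Compound 2 gives a number that sits at that same edge, so the two values show no difference that can be read.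

Compound 3, `COc1ccccc1NC(=O)Nc1cc(C)nc2ccccc12`, has not yet been measured. It differs from compound 1 in one place: methoxy in place of methylsulfanyl on an aromatic carbon. Both groups carry the same count of heavy atoms, no ring, no donor, one acceptor and no charge. Nothing measured here speaks to a change of this kind, so no step beyond the usual scatter is expected in this assay, in either direction.

Compound 3 is therefore expected to give 25000 nM, within 12000 nM to 50000 nM, which means an expected step of a number no higher from compound 1 to compound 3 (the limit leaves the size open).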

Compound 3, half-maximal effective concentration: > 25000 nM
Compound 3: a limit, no number; the forecaster's own chance of this, stated with the estimate: 70%; the middle value lies on the limit itself.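

In this assay compound 3 gives > 25000 nM, which is a limit of the assay and not a number. Compound 1 also stands at a limit, so no step can be read between compound 1 and compound 3, because both stop at the same edge: the limit of > 25000 nM in this assay, at which 2 of the 3 values shown sit.

The compounds shown leave open how methoxy and methylsulfanyl would compare at amounts beyond that edge.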